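Acetylating the Free Hydroxyl of a Nitrophenyl Sugar Derivative

This account rests on a few compounds, and the source may have more. Where it says the series, first, only, none or still open, it means among the compounds named here.

Of the compounds shown here, three have so far been measured in a functional assay on A549 cells (Homo sapiens) for antiproliferative activity, read by sulforhodamine B assay, with a stated time of 48 h; a lower number here means a stronger inhibitor of growth, a higher number a weaker inhibitor of growth. Compound 1 `Nc1nnc(SC[C@H]2O[C@@H](OCc3noc(-c4ccc(Cl)cc4)n3)[C@@H]3OC4(CCCC4)O[C@@H]32)s1` gives 15000 nM, compound 2 `O=[N+]([O-])c1ccc(-c2nc(CO[C@@H]3O[C@H](CO)[C@H]4OC5(CCCC5)O[C@@H]34)no2)cc1` gives 32000 nM, and compound 3 `CC1(C)O[C@H]2[C@H](OCc3noc(-c4ccc([N+](=O)[O-])cc4)n3)O[C@H](CSc3ncn[nH]3)[C@H]2O1` gives 90000 nM. On these numbers compound 2 stands second highest of the three: compound 1 sits at a lower number, a gap beyond the scatter, and compound 3 at a higher number, also beyond the scatter. Compound 4 `CC(=O)OC[C@H]1O[C@@H](OCc2noc(-c3ccc([N+](=O)[O-])cc3)n2)[C@@H]2OC3(CCCC3)O[C@@H]21` has not yet been measured. It differs from compound 2 by acetyl in place of hydrogen on an oxygen on a saturated carbon. For the measured compounds named here, no measured pair shows this change, so there is no basis for a step in either direction, and in this assay none beyond the scatter is expected. Compound 4 is therefore estimated at 28000 nM, within 9000 nM to 85000 nM, and that estimate means a step of a 1.1-fold lower number from compound 2 to compound 4 (0.06 log units; within the scatter).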

Compound 4, concentration for 50% growth inhibition: 29000 nM
Compound 4: the middle estimate sits 1.0-fold (0.02 log units) below what was measured, within the range that was stated.
By their numbers in this assay, from the lowest: compounds 1, 4 and 2 (each within the scatter of the next, the first and the last beyond it); then compound 3.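

For the compounds shown here, this is the first pair in this assay that differs in one place only. Acetyl in place of hydrogen on this oxygen gives a 1.1-fold lower number from compound 2 to compound 4 (0.04 log units; within the scatter), so at this position the free hydroxy is not required for the activity seen in compound 2, and the acetoxy group is tolerated equally well. No measurement offered here explains why the two compounds read alike.

As far as these compounds go, whether an amine or a carboxylic acid at this position would move the number stays open. So does whether the same acetyl change would read alike in the other compounds.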